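The source may hold more compounds than are shown below. What is called first, only, known or untested is meant among the compounds shown, and "the series" means these compounds.

Measured so far in a functional assay on MIA PaCa-2 cells (Homo sapiens) for inhibition, read by MTT assay, with a stated time of 3 days; a lower number here means a stronger inhibitor, a higher number a weaker inhibitor:
compound 1 `CCN(CC)S(=O)(=O)c1ccc(S(=O)(=O)N2CCC[C@@H](C(=O)N3CCS(=O)(=O)CC3)C2)cc1`: > 10000 nM
compound 2 `CCN(CC)S(=O)(=O)c1ccc(S(=O)(=O)N2CCC[C@@H](C(=O)N3CCC(O)CC3)C2)cc1`: > 10000 nM
compound 3 `CCN(CC)S(=O)(=O)c1ccc(S(=O)(=O)N2CCC[C@@H](C(=O)N[C@H]3CC[C@H](OC)CC3)C2)cc1`: > 10000 nM

Compound 3 stands at a limit of this assay: its reading > 10000 nM is a limit, not a number. For compound 1 the reading > 10000 nM is likewise a limit. For compound 2 the reading > 10000 nM is likewise a limit. All three values sit at the limit of > 10000 nM in this assay, at which 3 of the 3 values shown sit, so none of the three steps among them can be read: a step that the two limits leave unreadable from compound 1 to compound 2, a step that the two limits leave unreadable from compound 1 to compound 3, a step that the two limits leave unreadable from compound 2 to compound 3. Three different amide partners on the carbonyl carbon have therefore left the shared core without a measurable number.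

Compound 4 `CCN(CC)S(=O)(=O)c1ccc(S(=O)(=O)N2CCC[C@@H](C(=O)N3CCC(C(F)(F)F)CC3)C2)cc1` is the next amide partner. 4-(trifluoromethyl)piperidin-1-yl in place of (4-methoxycyclohexyl)amino on a carbonyl carbon

Going by the values given here, the steps that bear on this change are the three unreadable ones above; they give neither size nor direction, and nothing among the measured compounds shows that any amide partner pulls the series off the limit. The expected step that the limit leaves unreadable from compound 3 to compound 4 is accordingly set at no readable change, with compound 4 most likely returning a limit again. Compound 4 is expected to give 15000 nM in this assay, within 5000 nM to 60000 nM.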

Compound 4, half-maximal inhibitory concentration: > 10000 nM
Compound 4 gave a limit, no number; the forecaster's own chance of this, stated with the estimate: 80%; the middle value lies beyond the limit too.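

In this assay compound 4 gives > 10000 nM, a limit and not a number. No step from compound 1, compound 2 or compound 3 to compound 4 can be read: the limit of > 10000 nM in this assay, at which 4 of the 4 values shown sit.

The compounds shown leave open whether any amide partner on the shared core gives a measurable number.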